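From Azetidin-1-yl to Cyclopentylamino at the Assay Limit

The source may hold more compounds than are shown below. What is called first, only, known or untested is meant among the compounds shown, and "the series" means these compounds.

In a functional assay on ECa-109 cells for inhibition, with ECa-109 cell line (Homo sapiens) as the target, read by sulforhodamine B assay (on this read-out higher numbers stand for weaker inhibition and lower numbers for stronger inhibition), compound 1 (`O=C1C=C(N2CCC2)C(=O)c2c1nc1n2[C@H]2OC[C@@H](O)[C@H]2OC1`) gives > 16000 nM, which is a limit and not a number. Compound 1 therefore stands at the limit of > 16000 nM in this assay, at which 2 of the 3 values shown sit. Compound 2 (`O=C1C(NC2CCCC2)=CC(=O)c2c1nc1n2[C@H]2OC[C@@H](O)[C@H]2OC1`), which also carries cyclopentylamino, gives the limit > 16000 nM. Compound 3 (`O=C1C(Nc2ccc(Br)cc2)=CC(=O)c2c1nc1n2[C@H]2OC[C@@H](O)[C@H]2OC1`) measures 1980 nM. Compound 4 (`O=C1C=C(NC2CCCC2)C(=O)c2c1nc1n2[C@H]2OC[C@@H](O)[C@H]2OC1`) follows from compound 1 by cyclopentylamino in place of azetidin-1-yl on a double-bonded ring carbon, putting cyclopentylamino in place of azetidin-1-yl. For the measured compounds named here, the only measured step, an at least 8.0-fold lower number from compound 2 to compound 3 (0.90 log units; beyond the scatter), brings in 4-bromophenyl, which compound 4 lacks. No step beyond the scatter is therefore expected in this assay. For compound 4 the estimated value is 16000 nM, within an expected range of 6000 nM to 32000 nM. The expected change is a number no higher from compound 1 to compound 4 (the limit leaves the size open), and the readout may again be only a limit.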

Compound 4, half-maximal inhibitory concentration: > 16000 nM
Compound 4: no number, only a limit; the forecaster's own chance of this, stated with the estimate: 70%; the middle value sits exactly at the limit.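

In this assay, for the compounds shown here, compound 1 and compound 4 both read only as limits, so no step between them can be read: the limit of > 16000 nM in this assay, at which 3 of the 4 values shown sit. The compounds shown leave open what number either would give, and so whether cyclopentylamino in place of azetidin-1-yl changes inhibition at all.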